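This account rests on a few compounds, and the source may have more. Where it says the series, first, only, none or still open, it means among the compounds named here.

In a functional assay on K562 cells (Homo sapiens) for antiproliferative activity, read by MTT assay, with a stated time of 48 h (a lower number here means a stronger inhibitor of growth, a higher number a weaker inhibitor of growth), compound 2 `COc1cc(Cn2cnc3c(Cl)ncnc32)cc(OC)c1` gives > 100000 nM, which is a limit of the assay and not a number. Compound 3 `COc1cc(Cn2cnc3c(Cl)ncnc32)cc(OC)c1OC` differs from it by one change: methoxy in place of hydrogen on an aromatic carbon, a methoxy in place of hydrogen on an aromatic carbon, ortho to two methoxy groups. The same substituted group sits on a different core in compound 1 `COc1ccc(N(C)c2ncnc3c2ncn3Cc2cc(OC)c(OC)c(OC)c2)cc1`, which gives > 100000 nM, again a limit. Within the data shown here, no measured pair shows what this change does, so the expected step, an at least 2.0-fold lower number from compound 2 to compound 3 (0.30 log units; that floor lies within the scatter), is a modest one towards stronger growth inhibition. Compound 3 is estimated at 50000 nM, within an expected range of 10000 nM to 100000 nM.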

Compound 3, concentration for 50% growth inhibition: > 50000 nM
Compound 3 gave a limit, no number (the forecaster's own chance of this, stated with the estimate: 60%); the middle value lies on the limit itself.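

Among these compounds, compound 1, compound 2 and compound 3 all give limits rather than numbers, and no step from compound 2 to compound 3 or from compound 1 to compound 3 can be read. From the compounds shown here alone, whether the added methoxy changes growth inhibition at all remains open.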